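Swapping a methyl for a methoxyphenyl on the purine amine

This account rests on a few compounds, and the source may have more. Where it says the series, first, only, none or still open, it means among the compounds named here.

Compound 2 `CNc1ncnc2c1ncn2C1O[C@H](C(=O)O)[C@@H](O)[C@H]1O` gives 68 nM in an assay with adenosine receptor A1 (Rattus norvegicus) as the target (a higher number here means a weaker inhibitor, a lower number a stronger inhibitor), the higher of the two numbers measured here, and compound 1 `CCNC(=O)[C@H]1OC(n2cnc3c(Nc4ccc(OC)cc4)ncnc32)[C@H](O)[C@@H]1O` gives 4.6 nM. Compound 3 `COc1ccc(Nc2ncnc3c2ncn3C2O[C@H](C(=O)O)[C@@H](O)[C@H]2O)cc1` differs from compound 2 by 4-methoxyphenyl in place of methyl on a nitrogen on an aromatic ring. Among the compounds with values here, no measured pair shows this change alone, so the size of its effect is not known; compound 1 carries the same entering group with a different sugar end and gives a much lower number. A modest improvement is expected: a 2.7-fold lower number from compound 2 to compound 3 (0.43 log units; beyond the scatter). Compound 3 is therefore estimated at 25 nM, within 5 nM to 120 nM.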

Compound 3, half-maximal inhibitory concentration: 1 nM
For compound 3 the middle estimate is 25-fold (1.40 log units) above the measured one; measured number outside the range, below it.
By their numbers in this assay, from the lowest: compound 3; then compound 1; then compound 2.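

In this assay the group on the nitrogen carries far more weight than the methyl of compound 2 suggested: 4-methoxyphenyl in place of methyl gives a 68-fold lower number from compound 2 to compound 3 (1.83 log units; beyond the scatter) with the carboxylic acid end unchanged. With 4-methoxyphenyl held constant, hydroxy in place of ethylamino on the carbonyl carbon gives a 4.6-fold lower number from compound 1 to compound 3 (0.66 log units; beyond the scatter) as a smaller but real gain. No measurement here explains either step. Still open, from the compounds shown here alone, is how a plain phenyl or a benzyl would compare on that nitrogen, and whether a methyl ester would match the carboxylic acid.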